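Methoxy for tert-butyl in an indazolyl urea series

The source may hold more compounds than are shown below. What is called first, only, known or untested is meant among the compounds shown, and "the series" means these compounds.

Measured compounds in a functional assay for antagonist activity at transient receptor potential cation channel subfamily V member 1 (Homo sapiens), read by calcium flux; on this read-out higher numbers stand for weaker inhibition and lower numbers for stronger inhibition:
compound 1 `O=C(Nc1cccc2[nH]ncc12)NC1CCOc2ccccc21` 234 nM
compound 2 `CN1CCC(NC(=O)Nc2cccc3[nH]ncc23)c2ccccc21` 215 nM
compound 3 `CN1CCC(NC(=O)Nc2cccc3[nH]ncc23)c2cc(C(C)(C)C)ccc21` 853 nM

Compound 3 stands highest of the three numbers in this assay. Its nearest neighbour is compound 1, and its furthest is compound 2, both beyond the scatter below it. For the measured compounds named here, the single step among the measured compounds that bears on the next change is a 4.0-fold higher number from compound 2 to compound 3 (0.60 log units; beyond the scatter), which is what the tert-butyl group brought in at that aromatic carbon.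

Compound 4 `COc1ccc2c(c1)C(NC(=O)Nc1cccc3[nH]ncc13)CCN2C` is not yet measured. It differs from compound 3 by methoxy in place of tert-butyl on an aromatic carbon. Going by the values given here, no measured pair shows a methoxy at this position, so the only guide is that the tert-butyl, whose arrival raised the number in the step from compound 2 to compound 3, now leaves. The expectation is therefore that the number falls back part of the way toward compound 2, with the methoxy's own contribution unknown. For compound 4 in this assay the estimated step is a 2.7-fold lower number from compound 3 to compound 4 (0.43 log units; beyond the scatter), and the estimated value is 320 nM, within a range of 120 nM to 850 nM.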

Compound 4, half-maximal inhibitory concentration: 1380 nM
Estimate against measurement, compound 4: 4.3-fold (0.63 log units) below; the whole stated range lies below it.
By their numbers in this assay, from the lowest: compounds 2 and 1 (each within the scatter of the next); then compounds 3 and 4 (each within the scatter of the next).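

In this assay, the exchange of tert-butyl for methoxy gives a 1.6-fold higher number from compound 3 to compound 4 (0.21 log units; within the scatter) and so does not separate the two groups at this aromatic carbon, meta to a fused ring and para to a fused ring. Against the unsubstituted compound 2, methoxy gives a 6.4-fold higher number from compound 2 to compound 4 (0.81 log units; beyond the scatter) and tert-butyl gives a 4.0-fold higher number from compound 2 to compound 3 (0.60 log units; beyond the scatter) at the same place, so the higher number is not confined to tert-butyl but appears with both groups tried here. Nothing measured here accounts for this shared outcome.

The compounds shown leave open whether a fluorine, a chlorine or a hydroxyl at this carbon would stay near compound 2 or join compounds 3 and 4. They also leave open whether methoxy would give the same result on the core of compound 1.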